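A few compounds are considered here, and "the series" means these few. Any claim that something is new, unique, unknown or untested is made for them only; others in the source may bear on it.

In a functional assay on MCF7 cells (Homo sapiens) for cytotoxicity, read by MTT assay, with a stated time of 72 h (on this read-out higher numbers stand for weaker inhibition of growth and lower numbers for stronger inhibition of growth), three compounds of one family have been measured. Compound 1, `CCCCC[Se]c1nc([Se]CCCCC)c2cccnc2n1`, gives 67700 nM. Compound 3, `[SeH]c1nc([SeH])c2cccnc2n1`, gives 46100 nM. Compound 2, `Nc1nc([SeH])nc2ncccc12`, reaches only the limit of the assay, reported as > 100000 nM, so for compound 2 only a limit and no number is known; that is the limit of > 100000 nM in this assay, at which 1 of the 3 values shown sits. For the measured compounds named here, the single step between two compounds that differ in one place runs from compound 2 to compound 3, where one selenium atom replaces one nitrogen atom on an aromatic carbon, and it gives an at least 2.1-fold lower number from compound 2 to compound 3 (0.33 log units; beyond the scatter).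

Compound 4, `CCCCC[Se]c1nc(N)c2cccnc2n1`, has not yet been measured. It differs from compound 2 by pentyl in place of hydrogen on a selenium. Going by the values given here, no measured step covers this change: the only step, from compound 2 to compound 3, concerns a different kind of exchange, and compounds 1 and 3, which differ in both of their selenium substituents, show numbers not far apart in this assay. With compound 2 standing at a limit, the expectation for compound 4 is a number near that limit, with a step of about a number no higher from compound 2 to compound 4 (the limit leaves the size open) and no clear direction beyond the scatter. Compound 4 is therefore estimated at 100000 nM, within a range from 40000 nM to 250000 nM.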

Compound 4, concentration for total growth inhibition: 53800 nM
Compound 4: middle estimate off by 1.9-fold (0.27 log units), on the high side, within the range that was stated.
By their numbers in this assay, from the lowest: compounds 3, 4 and 1 (each within the scatter of the next). At a limit, above all of these: compound 2.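

For the compounds shown here, for the first time, a change on this selenium has its own step in this assay: pentyl in place of hydrogen gives an at least 1.8-fold lower number from compound 2 to compound 4 (0.26 log units; that floor lies within the scatter), so the step's floor alone does not separate the two compounds. As far as these compounds go, compound 2 has only a limit and not a number, so the full size of this step stays unknown: the limit of > 100000 nM in this assay, at which 1 of the 4 values shown sits. Going by these compounds alone, with pentyl held on one selenium, the other place on the core carries either a nitrogen atom or the selenium-bearing group of 6 heavy atoms, and this exchange, not covered by the earlier compounds, gives a 1.3-fold lower number from compound 1 to compound 4 (0.10 log units; within the scatter), so the two compounds cannot be told apart in this assay.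

The compounds shown leave open how a shorter chain such as methyl, a longer chain such as decyl, or a benzyl group on this selenium would read in this assay. Within the data shown here, they also leave open how pentyl in place of hydrogen on a selenium reads when the starting compound has a number rather than a limit, since the only such step here starts from a limit.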